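A few compounds are considered here, and "the series" means these few. Any claim that something is new, unique, unknown or untested is made for them only; others in the source may bear on it.

Working notes on the series. Compound 1 `COc1ccc(-c2cc3ccccc3nc2/C=C/C(=O)c2ccc(OC)cc2OC)cc1` gives 6260 nM in a functional assay on MCF7 cells (Homo sapiens) for antiproliferative activity, read by XTT assay, with a stated time of 72 h; on this read-out lower numbers stand for stronger inhibition and higher numbers for weaker inhibition. Going by the values given here, compound 2 `COc1ccc(-c2cc3ccccc3nc2/C=C/C(=O)c2ccc([N+](=O)[O-])cc2)cc1` gives 4110 nM in this assay, and the only measured step, a 1.5-fold lower number from compound 1 to compound 2 (0.18 log units; within the scatter), leaves the two compounds indistinguishable within the scatter. Compound 3 `COc1ccc(-c2cc3ccccc3nc2/C=C/C(=O)c2ccccn2)cc1` differs from compound 2 at the same position: pyridin-2-yl in place of 4-nitrophenyl on a carbonyl carbon. Among the compounds with values here, the single step that bears on this position stayed within the scatter, so no step beyond the scatter is expected in this assay for compound 3. Compound 3 is therefore estimated at 5000 nM, with a range of 1500 nM to 16000 nM. The expected step is a 1.2-fold higher number from compound 2 to compound 3 (0.09 log units; within the scatter).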

Compound 3, half-maximal inhibitory concentration: 810 nM
The estimate for compound 3 lay 6.2-fold (0.79 log units) above the measured number, and the stated range ends above it.
By their numbers in this assay, from the lowest: compound 3; then compounds 2 and 1 (each within the scatter of the next).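

In this assay the group on the carbonyl carbon can move the number beyond the scatter: pyridin-2-yl in place of 4-nitrophenyl gives a 5.1-fold lower number from compound 2 to compound 3 (0.71 log units; beyond the scatter), and pyridin-2-yl in place of 2,4-dimethoxyphenyl gives a 7.7-fold lower number from compound 1 to compound 3 (0.89 log units; beyond the scatter). Among the three compounds, only the changes that bring in the ring with a hetero atom go beyond the scatter, whereas the exchange of one substituted phenyl for the other gives a 1.5-fold lower number from compound 1 to compound 2 (0.18 log units; within the scatter). Nothing available explains these steps. On these data alone, it remains open whether the ring nitrogen of pyridin-2-yl carries the step, a question that a plain phenyl or a pyridin-4-yl on the carbonyl carbon would address.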